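The source may hold more compounds than are shown below. What is called first, only, known or untested is meant among the compounds shown, and "the series" means these compounds.

In a functional assay on M21 cells (Homo sapiens) for antiproliferative activity, read by sulforhodamine B assay, with a stated time of 48 h (a higher number here means a weaker inhibitor, a lower number a stronger inhibitor), three compounds that share one core have been read so far. Compound 1 `CCCN1CCN(c2ccc(S(=O)(=O)Oc3ccccc3C)cc2)C1=O` gives > 100000 nM, which is a limit of the assay and not a number. Compound 2 `CCCN1CCN(c2ccc(S(=O)(=O)Oc3cccc(C)c3)cc2)C1=O` gives 28000 nM. Compound 3 `CCCN1CCN(c2ccc(S(=O)(=O)Oc3cccc(Cl)c3)cc2)C1=O` gives 8600 nM, the lowest number of the three. Its nearest neighbour lies behind it by a 3.3-fold lower number from compound 2 to compound 3 (0.51 log units; beyond the scatter), and the gap to the limit compound is an at least 11-fold lower number from compound 1 to compound 3 (1.06 log units; beyond the scatter).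

Compound 4 `CCCN1CCN(c2ccc(S(=O)(=O)Oc3ccc(C)cc3)cc2)C1=O` has not yet been measured. It carries 4-methylphenyl in place of 3-chlorophenyl on an oxygen.

Within the data shown here, two measured steps bear on this change. The exchange of methyl for chloro gave a 3.3-fold lower number from compound 2 to compound 3 (0.51 log units; beyond the scatter), so a return to methyl points towards a higher number. The other step, an at least 3.5-fold lower number from compound 1 to compound 2 (0.55 log units; beyond the scatter), shows that the place of the methyl matters among these compounds, although 4-methylphenyl itself has no measured precedent. A modest step towards a higher number is therefore expected in this assay, with wide uncertainty in either direction. The expectation is a 2.6-fold higher number from compound 3 to compound 4 (0.41 log units; beyond the scatter). For compound 4 the estimated value is 22000 nM, with an expected range from 6000 nM to 80000 nM.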

Compound 4, half-maximal inhibitory concentration: 28000 nM
Estimate against measurement, compound 4: 1.3-fold (0.10 log units) below; low and high end bracket the measured number.
By their numbers in this assay, from the lowest: compound 3; then compounds 2 and 4 (each within the scatter of the next). At a limit, above all of these: compound 1.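

With 4-methylphenyl in place of 3-methylphenyl on the oxygen whose other neighbour is the sulfonyl sulfur, this assay shows no change at the digits printed from compound 2 to compound 4 (within the scatter), so the two methyl groups cannot be told apart here, and 4-methylphenyl does not share the standing of 2-methylphenyl. The value of compound 1 is a limit of the assay and not a number: the limit of > 100000 nM in this assay, at which 1 of the 4 values shown sits. Even against that limit, 4-methylphenyl in place of 2-methylphenyl gives an at least 3.5-fold lower number from compound 1 to compound 4 (0.55 log units; beyond the scatter), while 4-methylphenyl in place of 3-chlorophenyl gives a 3.3-fold higher number from compound 3 to compound 4 (0.51 log units; beyond the scatter), so among the compounds with a measured number, 3-chlorophenyl alone separates from both 3-methylphenyl and 4-methylphenyl.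

The compounds shown leave open whether 4-chlorophenyl or 2-chlorophenyl would stand with compound 3 or with compound 4, as chloro has been read in the 3-chlorophenyl group only. They also leave open how a methoxy group, an amine or a carboxylic acid on the phenyl ring, or a longer chain on the shared core, would read in this assay.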